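Methyl in place of hydrogen on the ring of compound 1

The source may report more compounds than this note shows. Statements on the series, on what has been measured and on what is new or still open speak of the compounds shown alone.

Compound 1 `CCOC(=O)C(=O)Nc1cccccc1=O` stands highest of the two numbers in hand: in a functional assay on the whole organism (strain Sprague-Dawley CD) for inhibition, with Rattus norvegicus as the target, read by paw edema, at a dose of 100 mg/kg by the oral route (a lower number here means a weaker effect, a higher number a stronger effect of the compound at the dose given), compound 1 gives 91%. Its nearest neighbour, compound 2 `CCOC(=O)C(=O)Nc1c(Oc2ccccc2)ccccc1=O`, gives 20% in this assay, the step between them being a number 71 percentage points lower from compound 1 to compound 2 (beyond the scatter).

Compound 3 `CCOC(=O)C(=O)Nc1ccccc(C)c1=O` differs from compound 1 in one place: methyl in place of hydrogen on an aromatic carbon. Within the data shown here, the only measured step, a number 71 percentage points lower from compound 1 to compound 2 (beyond the scatter), concerns a different group at a different place on the ring, so it bears on compound 3 only loosely; it shows that substitution on this ring can cut the read-out sharply, but the entering group here is methyl, with no ring, far smaller than phenoxy. The expected step is therefore a moderate drop, a number 21 percentage points lower from compound 1 to compound 3 (beyond the scatter), with wide uncertainty. Compound 3 is estimated at 70%, in the range 40% to 95%.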

Compound 3, a percentage reported as inhibition, in the whole organism at one dose (the size of the read-out at that dose, not a potency): 34%
Compound 3: the middle estimate sits 36 percentage points above what was measured; the measured number lies below the stated range.
By their numbers in this assay, from the lowest: compound 2; then compound 3; then compound 1.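

In this assay the step of a number 57 percentage points lower from compound 1 to compound 3 (beyond the scatter) shows that methyl, with 1 heavy atom and no ring, is enough for a large loss on this aromatic carbon, two ring bonds from the ring atom that bears a group of 8 heavy atoms. The earlier step of a number 71 percentage points lower from compound 1 to compound 2 (beyond the scatter) involved phenoxy at a different place on the ring, so it could not show that so small a group at this position has such an effect. No measurement in hand bears on why the read-out falls here.

As far as these compounds go, it remains open whether a hydroxyl, an amine or a longer chain at this position would give a similar loss. Methyl on the other ring carbons also remains open, so the compounds shown do not settle whether this loss is particular to this position.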